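Aryl change on the triazole of the spiro series

This account rests on a few compounds, and the source may have more. Where it says the series, first, only, none or still open, it means among the compounds named here.

Compound 2 `N#CC1=C(N)Oc2c(N)cc3nc4ccccc4nc3c2C12C(=O)N(Cc1cnnn1-c1cc(Cl)ccc1Cl)c1ccccc12` stands at the lower of the two numbers measured in a functional assay on A549 cells (Homo sapiens) for antiproliferative activity, read by MTT assay, with a stated time of 48 h; on this read-out lower numbers stand for stronger inhibition and higher numbers for weaker inhibition; in that assay compound 2 gives 10900 nM. Among the measured compounds shown here, compound 1 `N#CC1=C(N)Oc2c(N)cc3nc4ccccc4nc3c2C12C(=O)N(Cc1cnnn1-c1ccccc1Br)c1ccccc12` gives 27400 nM, and the single measured step, a 2.5-fold lower number from compound 1 to compound 2 (0.40 log units; beyond the scatter), concerns only a change of the aryl group on the aromatic nitrogen. Compound 3 `N#CC1=C(N)Oc2c(N)cc3nc4ccccc4nc3c2C12C(=O)N(Cc1cnnn1-c1ccc([N+](=O)[O-])cc1[N+](=O)[O-])c1ccccc12` carries 2,4-dinitrophenyl in place of 2,5-dichlorophenyl on an aromatic nitrogen. For the measured compounds named here, that one step is the only guide and it involves a different group, so no step beyond the scatter is expected here, in either direction. For compound 3 the estimate in this assay is 12000 nM, with a range of 4000 nM to 40000 nM. The expected step of a 1.1-fold higher number from compound 2 to compound 3 (0.04 log units; within the scatter) is accordingly small.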

Compound 3, half-maximal inhibitory concentration: > 50000 nM
Compound 3: no number, only a limit; the forecaster's own chance of this, stated with the estimate: 5%; middle value at least 4.1-fold (0.61 log units) away from the limit.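

In this assay the reading for compound 3 is a limit and not a number: the limit of > 50000 nM in this assay, at which 1 of the 3 values shown sits. On this aromatic nitrogen, 2,4-dinitrophenyl in place of 2,5-dichlorophenyl gives an at least 4.5-fold higher number from compound 2 to compound 3 (0.66 log units; beyond the scatter), so the aryl group here can move the read-out further than the modest step between the two halogenated compounds showed. Against 2-bromophenyl the same group gives an at least 1.8-fold higher number from compound 1 to compound 3 (0.26 log units; that floor lies within the scatter), which leaves compound 1 and compound 3 unordered.

Still open, going by these compounds, is the true size of both steps. Also open, on these data alone, is whether a single nitro group, an amine or a methoxy group on this aryl ring would keep the level of compound 2.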